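The source may hold more compounds than are shown below. What is called first, only, known or untested is meant among the compounds shown, and "the series" means these compounds.

Measured in an ADME assay on MDBK cells (Bos taurus) for cytotoxicity, read by MTT assay, with a stated time of 96 h; a lower number here means that less compound is tolerated, a higher number that more compound is tolerated:
- Compound 1 `CC(=O)NC(=S)Nc1cccc(C(F)(F)F)c1`: > 100000 nM (a limit)
- Compound 2 `FC(F)(F)c1cccc(NC(=S)Nc2cccc(Br)c2)c1`: 10000 nM
- Compound 3 `C=C(C)CNC(=S)Nc1cccc(C(F)(F)F)c1`: > 100000 nM (a limit)

Compound 3 stands at > 100000 nM, which is a limit of the assay and not a number. It is not alone there, as the set shows (the limit of > 100000 nM in this assay, at which 2 of the 3 values shown sit).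

Compound 4 `CSCCCNC(=S)Nc1cccc(C(F)(F)F)c1` alters only the chain of compound 3: 2-(methylsulfanyl)ethyl in place of 1-methylethenyl on a saturated chain carbon bound to an amide-type nitrogen. The entering 2-(methylsulfanyl)ethyl carries no ring, and neither does the 1-methylethenyl it replaces.

Among the compounds with values here, no measured step makes this exact change, so the evidence is indirect. Within the data shown here, the only readable number comes from compound 2, with its 3-bromophenyl group, and the steps to and from it are large: an at least 10-fold lower number from compound 1 to compound 2 (1.00 log units; beyond the scatter), and an at least 10-fold higher number from compound 2 to compound 3 (1.00 log units; beyond the scatter). The remaining step gives no size: a step that the two limits leave unreadable from compound 1 to compound 3. In this assay, compound 4 keeps the chain-type substituent of compound 3 and gains no 3-bromophenyl, so a drop of the size seen with compound 2 is not expected. No step beyond the scatter is expected, and a report of only a limit is somewhat more likely than a number. The expected change is an at least 1.1-fold lower number from compound 3 to compound 4 (0.04 log units; that floor lies within the scatter). For compound 4 the estimated value is 90000 nM, with an expected range from 30000 nM to 200000 nM.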

Compound 4, half-maximal cytotoxic concentration: > 100000 nM
Compound 4: only a limit was reported (the forecaster's own chance of this, stated with the estimate: 55%); middle value at least 1.1-fold (0.04 log units) from the limit.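

In this assay, the 3-(methylsulfanyl)propyl chain of compound 4 brings a sulfur and a hydrogen-bond acceptor that the 2-methylprop-2-en-1-yl of compound 3 lacks, yet its reading is again a limit of the assay and not a number: the limit of > 100000 nM in this assay, at which 3 of the 4 values shown sit. The same chain gives an at least 10-fold higher number from compound 2 to compound 4 (1.00 log units; beyond the scatter), so a second chain without a ring on this amide-type nitrogen now stands clear of the 3-bromophenyl group of compound 2, the only compound shown with a readable number. The steps among compound 1, compound 3 and compound 4 cannot be read, as each joins two limits.

The limits leave open how compound 1, compound 3 and compound 4 compare with one another, and whether any chain at this place reaches a readable number. As far as these compounds go, how an amine or a carboxylic acid at the end of the propyl chain, or a longer chain, would read in this assay also remains open.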